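Swapping 3-Methoxyphenyl for 2-Methylphenyl on a Shared Core

This account rests on a few compounds, and the source may have more. Where it says the series, first, only, none or still open, it means among the compounds named here.

Going by the values given here, in a physicochemical assay for pharmacokinetics (a higher number here means that the compound lasts longer, a lower number that the compound disappears faster), compound 1 `COc1cccc(CNC(=O)N2C(=O)c3ccccc3S2(=O)=O)c1` gives 0.523 h as the only actual number so far. In this assay compound 2 `O=C(OCc1ccccc1)N1C(=O)c2ccccc2S1(=O)=O` gives < 0.0167 h which is a limit and not a number. Compound 3 `Cc1ccccc1CNC(=O)N1C(=O)c2ccccc2S1(=O)=O` keeps the core of compound 1 but carries 2-methylphenyl in place of 3-methoxyphenyl on a saturated chain carbon bound to an amide-type nitrogen. Among the compounds with values here, no measured step covers such a swap, so the expectation rests on compound 1 at 0.523 h and foresees no shift beyond the scatter in either direction. The estimated change is a 1.0-fold lower number from compound 1 to compound 3 (0.02 log units; within the scatter) in this assay for now. Compound 3 is expected at 0.5 h with a range of 0.17 h to 1.5 h as its likely span.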

Compound 3, half-life: 0.792 h
Estimate against measurement, compound 3: 1.6-fold (0.20 log units) below; measured number inside the range.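

In this assay, going by these compounds alone, this step gives the first reading at this position, on a saturated chain carbon bound to an amide-type nitrogen: a 1.5-fold higher number from compound 1 to compound 3 (0.18 log units; within the scatter). Exchanging 3-methoxyphenyl for 2-methylphenyl, and with it the one counted hydrogen-bond acceptor, therefore leaves the half-life within the scatter. Nothing shown bears on why this swap has so small an effect. On these data alone, it remains open whether a group of another kind in this place, such as an amine or a carboxylic acid, would move the half-life beyond the scatter.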